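A few compounds are considered here, and "the series" means these few. Any claim that something is new, unique, unknown or untested is made for them only; others in the source may bear on it.

Working notes on the series. Of the compounds shown here, two in this set have been measured. Compound 1 `COc1ccc(-c2nn(-c3ccccc3)cc2C(=O)NC(=S)Nc2ccc(F)cc2)cc1` gives 1430 nM in a functional assay on A549 cells (Homo sapiens) for inhibition, read by CCK-8 assay, with a stated time of 48 h; a lower number here means a stronger inhibitor, a higher number a weaker inhibitor. Compound 2 `COc1ccc(-c2nn(-c3ccccc3)cc2C(=O)NC(=S)Nc2ccc(Cl)cc2)cc1` gives 1310 nM in this assay. Among the compounds with values here, the only step between them, a 1.1-fold lower number from compound 1 to compound 2 (0.04 log units; within the scatter), is a change of one halogen for another on the aromatic ring at the far end of the thiourea; the two numbers cannot be told apart. Compound 2 therefore stands at the lower of the two numbers shown, but not apart from compound 1.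

The next compound, compound 3 `COc1ccc(-c2nn(-c3ccccc3)cc2C(=O)NC(=S)Nc2ccc(C)cc2)cc1`, keeps the shared core of compound 2 and changes only the group at that same position: methyl in place of chloro on an aromatic carbon. Within the data shown here, no measured step covers a methyl at this position, so the only step that bears on it is a 1.1-fold lower number from compound 1 to compound 2 (0.04 log units; within the scatter), which shows that swapping one small substituent for another there left the number within the scatter. On that basis no step beyond the scatter is expected in this assay, in either direction, and the step of a 1.1-fold higher number from compound 2 to compound 3 (0.03 log units; within the scatter) is the expectation. Compound 3 is estimated at 1400 nM, with a range of 700 nM to 2800 nM.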

Compound 3, half-maximal inhibitory concentration: 1250 nM
Estimate against measurement, compound 3: 1.1-fold (0.05 log units) above, within the range that was stated.
By their numbers in this assay, from the lowest: compounds 3, 2 and 1 (each within the scatter of the next).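

Compound 3 adds a carbon substituent to the two halogens already seen at this place on the aromatic ring, para to a large group. In this assay the change to methyl gives a 1.0-fold lower number from compound 2 to compound 3 (0.02 log units; within the scatter) and, set against the fluoro end of the set, a 1.1-fold lower number from compound 1 to compound 3 (0.06 log units; within the scatter), so both steps stay within the scatter and fluoro, chloro and methyl cannot be told apart here. Methyl in place of a halogen on this aromatic carbon therefore leaves the number where the halogens put it, and nothing measured on hand accounts for this flat result.

As far as these compounds go, the three compounds show only these single-atom-sized groups at one place, so it remains open whether a methoxy, an amine, a carboxylic acid, a longer chain such as butyl, or plain hydrogen there would give a step beyond the scatter. Also open, from the compounds shown here alone, is whether the number responds to any change outside this place, such as a urea in place of the thiourea or a different group on the shared core.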